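This account rests on a few compounds, and the source may have more. Where it says the series, first, only, none or still open, it means among the compounds named here.

Compound 1, `S=C(Nc1cccnc1)NC1CCN(c2cc(OCc3ccccc3)ccn2)CC1`, gives 2800 nM in an assay on membranes from brain for binding affinity to Lysophosphatidylserine lipase ABHD12 (Mus musculus), read by fluorescence, with a stated time of 20 min; a higher number here means a weaker inhibitor, a lower number a stronger inhibitor.
Compound 2, `FC(F)(F)Oc1ccc(Oc2ccnc(N3CCC[C@H](NC(=S)Nc4cccnc4)C3)c2Cl)c(Cl)c1`, reaches only the limit > 100000 nM in this assay.
Compound 3, `S=C(Nc1cccnc1)NC1CCN(c2cc(Cl)ccn2)CC1`, gives 2100 nM in this assay.

Of the two numbers that this assay has yielded, compound 3 carries the lower one, and the nearest to it is compound 1, whose step a 1.3-fold lower number from compound 1 to compound 3 (0.12 log units; within the scatter) lies within the scatter, so the two compounds are not told apart by this assay. Compound 2 stands apart from both, since its result is a limit and not a number, as the limit of > 100000 nM in this assay, at which 1 of the 3 values shown sits, records.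

Compound 4, `COc1ccnc(N2CCC(NC(=S)Nc3cccnc3)CC2)c1`, is not yet measured in this assay. It is reached from compound 3 by the change (methoxy in place of chloro on an aromatic carbon). For the measured compounds named here, the one measured step that bears on this position is the one from compound 1 to compound 3, where benzyloxy gave way to chloro and the number moved by a 1.3-fold lower number from compound 1 to compound 3 (0.12 log units; within the scatter), within the scatter. A methoxy in place of chloro at the same carbon is therefore expected to leave the number of compound 4 close to that of compound 3, with the step of a 1.2-fold higher number from compound 3 to compound 4 (0.08 log units; within the scatter) not expected to exceed the scatter. For compound 4 the estimate in this assay is 2500 nM, with a likely range from 1000 nM to 6500 nM.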

Compound 4, half-maximal inhibitory concentration: > 5000 nM
Compound 4 ended at the assay's limit; the forecaster's own chance of this, stated with the estimate: 5%; middle value at least 2.0-fold (0.30 log units) away from the limit.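

Methoxy in place of chloro on the aromatic carbon opposite the ring nitrogen gives an at least 2.3-fold higher number from compound 3 to compound 4 (0.37 log units; beyond the scatter) in this assay, so this position does respond to a change of group, which the earlier step from benzyloxy to chloro had not shown. The size of that step has only a floor, since compound 4 carries a limit and not a number: the limit of > 5000 nM in this assay, at which 1 of the 4 values shown sits. An oxygen on this carbon does not by itself go with the weaker result, as compound 1 also has one there and a 1.3-fold lower number from compound 1 to compound 3 (0.12 log units; within the scatter), while the comparison with the benzyloxy group gives an at least 1.7-fold higher number from compound 1 to compound 4 (0.25 log units; that floor lies within the scatter), which does not set those two compounds apart.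

How far compound 4 really lies from compound 1 therefore remains open, and so does what lies behind the step from chloro to methoxy. Also open, going by these compounds, is whether an amine, a fluoro group or a longer alkoxy chain on the same carbon would stay level with chloro or go the way of methoxy.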